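This account rests on a few compounds, and the source may have more. Where it says the series, first, only, none or still open, it means among the compounds named here.

Compound 3 `CS(=O)(=O)Nc1ccc2c(c1)S(=O)(=O)N=C(C1=C(O)C3CCCC3N(Cc3ccc(Cl)cc3)C1=O)N2` stands in an ADME assay on Huh-7 cells (Homo sapiens) for cytotoxicity, with a stated time of 72 h (a lower number here means that less compound is tolerated, a higher number that more compound is tolerated), at a value that is a limit of the assay and not a number: compound 3 gives > 10000 nM. Two related compounds have also been measured in this assay. Compound 1 `CS(=O)(=O)Nc1ccc2c(c1)S(=O)(=O)N=C(C1=C(O)C3CCCC3N(CCC3CC3)C1=O)N2` gives > 33000 nM, which is again a limit of the assay. Compound 2 `CC(C)CCN1C(=O)C(C2=NS(=O)(=O)c3cc(NS(C)(=O)=O)ccc3N2)=C(O)C2CCCC21` gives > 1000 nM, once more a limit. Where compound 3 stands among these three cannot be read, because all of them sit at limits, namely (the limit of > 1000 nM in this assay, at which 1 of the 3 values shown sits), the limit of > 10000 nM in this assay, at which 1 of the 3 values shown sits, and (the limit of > 33000 nM in this assay, at which 1 of the 3 values shown sits).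

Compound 4 `CC(C)N1C(=O)C(C2=NS(=O)(=O)c3cc(NS(C)(=O)=O)ccc3N2)=C(O)C2CCCC21` differs from compound 3 in one place: isopropyl in place of 4-chlorobenzyl on an amide-type nitrogen in a ring. The measured steps that bear on this change are a step that the two limits leave unreadable from compound 1 to compound 2, a step that the two limits leave unreadable from compound 1 to compound 3 and a step that the two limits leave unreadable from compound 2 to compound 3, and none of them has a readable size. The expectation for compound 4 in this assay is therefore no step beyond the scatter that the numbers could reveal, and most likely yet another limit. For compound 4 the expected step in this assay is a step that the limit leaves unreadable from compound 3 to compound 4. Compound 4 is estimated at 20000 nM, with a range from 3000 nM to 100000 nM.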

Compound 4, half-maximal cytotoxic concentration: > 33000 nM
Compound 4 was reported as a limit; the forecaster's own chance of this, stated with the estimate: 80%; middle value at least 1.6-fold (0.21 log units) from the limit.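

In this assay compound 4 gives > 33000 nM, which is a limit of the assay. The values of compound 1, compound 2 and compound 3 are limits too, and no step among these four can be read. The compounds shown leave open whether the group on the amide-type nitrogen in a ring changes this value at all.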